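Swapping a chloro ring for a methoxy-bearing ring

The compounds below may be only part of what the source reports. "The series", "measured", "known", "first", "only" and "open" are said of these compounds alone.

In a functional assay on HCT-116 cells (Homo sapiens) for antiproliferative activity, read by MTT assay, with a stated time of 48 h (a lower number here means a stronger inhibitor, a higher number a weaker inhibitor), compound 3 `COc1cc(N(Cc2ccc(Cl)cc2)C(=O)CSc2nc3ccccc3s2)cc(OC)c1OC` gives 603000 nM, the weakest of the three measured, against compound 2 `COc1ccc(CN(C(=O)CSc2nc3ccccc3s2)c2cc(OC)c(OC)c(OC)c2)cc1` at 426 nM and compound 1 `COc1ccc(CN(C(=O)CSc2nc3ccccc3s2)c2cc(OC)c(OC)c(OC)c2)cc1N=[N+]=[N-]` at 2860 nM. Compound 4 `COc1ccc(CN(C(=O)CSc2nc3ccccc3s2)c2cc(OC)c(OC)c(OC)c2)cc1C(F)(F)F` departs from compound 3 on a saturated chain carbon bound to an amide-type nitrogen: 4-methoxy-3-(trifluoromethyl)phenyl in place of 4-chlorophenyl on a saturated chain carbon bound to an amide-type nitrogen. Going by the values given here, three measured steps bear on this change. Chloro in place of methoxy gave a large step, a 1400-fold higher number from compound 2 to compound 3 (3.15 log units; beyond the scatter), and replacing the azido-bearing ring gave another, a 210-fold higher number from compound 1 to compound 3 (2.32 log units; beyond the scatter). Hydrogen in place of azido gave a modest one, a 6.7-fold lower number from compound 1 to compound 2 (0.83 log units; beyond the scatter), while trifluoromethyl itself remains untested. A large step to a lower number is therefore expected, a 300-fold lower number from compound 3 to compound 4 (2.48 log units; beyond the scatter). Compound 4 is estimated at 2000 nM, within an expected range of 400 nM to 10000 nM.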

Compound 4, half-maximal inhibitory concentration: > 80000 nM
Compound 4 ended at the assay's limit; the forecaster's own chance of this, stated with the estimate: 3%; middle value at least 40-fold (1.60 log units) from the limit.
By their numbers in this assay, from the lowest: compound 2; then compound 1; then compound 3.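

In this assay compound 4 gives a limit, not a number: the limit of > 80000 nM in this assay, at which 1 of the 4 values shown sits. Even so, trifluoromethyl in place of hydrogen on an aromatic carbon gave an at least 180-fold higher number from compound 2 to compound 4 (2.27 log units; beyond the scatter), and trifluoromethyl in place of azido gave an at least 27-fold higher number from compound 1 to compound 4 (1.44 log units; beyond the scatter), so the 4-methoxy-3-(trifluoromethyl)phenyl ring does not keep the numbers of the other two methoxy-bearing rings. The step from compound 3 cannot be read.

The compounds shown leave open how an amine, a hydroxyl or a methyl at that aromatic carbon would read. As far as these compounds go, the true number of compound 4 also remains open.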